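This account rests on a few compounds, and the source may have more. Where it says the series, first, only, none or still open, it means among the compounds named here.

Three compounds share one core and differ only in a small group on a single aromatic carbon. In a functional assay for inhibition, with Homo sapiens as the target (a higher number here means a weaker inhibitor, a lower number a stronger inhibitor), compound 1 `OCc1cc(-c2ccccc2)c2ccc(OCc3cccc(C4(O)CCOCC4)c3)cc2c1` gives 9 nM, compound 2 `CC(O)c1cc(-c2ccccc2)c2ccc(OCc3cccc(C4(O)CCOCC4)c3)cc2c1` gives 28 nM, and compound 3 `COCc1cc(-c2ccccc2)c2ccc(OCc3cccc(C4(O)CCOCC4)c3)cc2c1` gives 4 nM. Compound 3 thus has the lowest number of the three: the step of a 2.3-fold lower number from compound 1 to compound 3 (0.35 log units; beyond the scatter) went beyond the scatter, and the step of a 7.0-fold lower number from compound 2 to compound 3 (0.85 log units; beyond the scatter) was larger still. The remaining step, a 3.1-fold higher number from compound 1 to compound 2 (0.49 log units; beyond the scatter), pushed the number up.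

Compound 4 `CC(=O)c1cc(-c2ccccc2)c2ccc(OCc3cccc(C4(O)CCOCC4)c3)cc2c1` is the next step from compound 3, with the change (acetyl in place of methoxymethyl on an aromatic carbon). Among the measured compounds shown here, no measured step swaps exactly these two groups, so the two nearest steps must serve as a guide: the gain from compound 1 to compound 3 and the loss from compound 1 to compound 2 were both modest, and neither was large. A modest change in either direction is therefore expected for compound 4 in this assay, leaning slightly toward a higher number than compound 3, so the estimated step is a 2.3-fold higher number from compound 3 to compound 4 (0.35 log units; beyond the scatter). Compound 4 is expected to give about 9 nM, within a range from 3 nM to 30 nM.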

Compound 4, half-maximal inhibitory concentration: 2 nM
Beside the measured number, compound 4's estimate is 4.5-fold (0.65 log units) above it, and the stated range ends above it.
By their numbers in this assay, from the lowest: compounds 4 and 3 (each within the scatter of the next); then compound 1; then compound 2.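

Acetyl and methoxymethyl, which have the same counts of heavy atoms, hydrogen-bond donors and acceptors, cannot be told apart at this aromatic carbon in this assay, as the step of a 2.0-fold lower number from compound 3 to compound 4 (0.30 log units; within the scatter) shows. Acetyl also carries a methyl group, yet it sits well on the favourable side of both hydroxyl-bearing groups, with a 14-fold lower number from compound 2 to compound 4 (1.15 log units; beyond the scatter) and a 4.5-fold lower number from compound 1 to compound 4 (0.65 log units; beyond the scatter), so the extra methyl of compound 2 does not by itself bring a higher number here. No measurement offered here explains why the carbonyl of compound 4 and the hydroxyl of compound 2 differ so much. From the compounds shown here alone, whether an amine, a carboxylic acid or a longer chain such as propanoyl at this carbon would keep the number this low remains open. So does whether these differences would hold with other changes elsewhere on the shared core.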